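This account rests on a few compounds, and the source may have more. Where it says the series, first, only, none or still open, it means among the compounds named here.

Measured so far in a functional assay on CHO cells for agonist activity at Free fatty acid receptor 1 (Homo sapiens), read by FLIPR and calcium flux; on this read-out higher numbers stand for an effect only at larger amounts of compound and lower numbers for an effect already at smaller amounts:
- compound 1, `O=C(O)CS(=O)(=O)c1ccc(OCc2cccc(-c3ccccc3)c2)cc1`: compound 1 gives 288 nM
- compound 2, `O=C(O)CS(=O)(=O)c1ccc(OCc2cccc(-c3ccccc3Cl)c2)cc1`: compound 2 gives 28.8 nM
- compound 3, `Cc1noc(C)c1-c1cccc(COc2ccc(S(=O)(=O)CC(=O)O)cc2)c1`: compound 3 gives 269 nM

Compound 2 differs from compound 1 by chloro in place of hydrogen on an aromatic carbon, and this step is a 10-fold lower number from compound 1 to compound 2 (1.00 log units; beyond the scatter). The two cores differ as shown by 3,5-dimethyl-1,2-oxazol-4-yl in place of phenyl on an aromatic carbon; the step is a 1.1-fold lower number from compound 1 to compound 3 (0.03 log units; within the scatter), so compound 1 and compound 3 cannot be ordered. Between the other pair the step is a 9.3-fold higher number from compound 2 to compound 3 (0.97 log units; beyond the scatter).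

Compound 4, `Cc1noc(C)c1-c1cc(COc2ccc(S(=O)(=O)CC(=O)O)cc2)ccc1Cl`, is not yet measured. It differs from compound 3 by chloro in place of hydrogen on an aromatic carbon. This is the same kind of change as from compound 1 to compound 2, occurring twice among the compounds shown, but the place is not identical: in compound 2 the chloro is ortho to a large group, in compound 4 it is ortho to a 3,5-dimethyl-1,2-oxazol-4-yl group and para to a large group. For compound 4 a step in the same direction is expected, a 6.0-fold lower number from compound 3 to compound 4 (0.78 log units; beyond the scatter), because the earlier chloro step gave a 10-fold lower number from compound 1 to compound 2 (1.00 log units; beyond the scatter), tempered for the different place. Compound 4 is estimated at 45 nM, between 15 nM and 150 nM.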

Compound 4, half-maximal effective concentration: 214 nM
The estimate for compound 4 lay 4.8-fold (0.68 log units) below the measured number; measured number above the stated range.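

In this assay the chloro step on the core of compound 3 is a 1.3-fold lower number from compound 3 to compound 4 (0.10 log units; within the scatter) and so compound 3 and compound 4 cannot be ordered. The clear drop in the number seen with chloro on the core of compound 1 therefore does not carry over to the core of compound 3, and the two steps differ by more than scatter alone would give: the same change on two cores in this assay, a 10-fold lower number (1.00 log units; beyond the scatter) from compound 1 to compound 2 and a 1.3-fold lower number (0.10 log units; within the scatter) from compound 3 to compound 4, 8.0-fold (0.90 log units) apart, beyond the scatter of two such steps. This rests on one pair for each core, and in compound 4 the chloro stands ortho to a 3,5-dimethyl-1,2-oxazol-4-yl group and para to a large group, so the data do not separate an effect of the core from an effect of the place of the chloro.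

The compounds shown leave open whether chloro at another place on the core of compound 3 would give a step like the one from compound 1 to compound 2. They also leave open whether a fluoro, methyl or methoxy group in place of the chloro would follow the same split between the two cores.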